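The compounds below may be only part of what the source reports. "The series", "measured", "known", "first", "only" and "open" are said of these compounds alone.

Two compounds in this set share one core and carry the same amide tail, an oxygen-linked benzyl group. Compound 1 `Cc1ccc(-c2nn(-c3ccccc3)cc2C(=O)NOCc2ccccc2)cc1` bears an unsubstituted benzyl ring, and in a functional assay on HeLa cells (Homo sapiens) for antiproliferative activity, read by MTT assay, with a stated time of 48 h, in the presence of a further agent that is not named here (on this read-out higher numbers stand for weaker inhibition of growth and lower numbers for stronger inhibition of growth), compound 1 gives 6690 nM. Compound 2 `Cc1ccc(-c2nn(-c3ccccc3)cc2C(=O)NOCc2ccccc2Cl)cc1` adds a chloro group to that ring, and in this assay compound 2 gives 4680 nM. Among the compounds with values here, the step of a 1.4-fold lower number from compound 1 to compound 2 (0.16 log units; within the scatter) is the only measured step here, and it stays within the scatter, so the two numbers cannot be told apart. Compound 2 has the lowest number of the two, with compound 1 the nearest at a gap that is also within the scatter.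

Compound 3 `O=C(NOCc1ccccc1Cl)c1cn(-c2ccccc2)nc1-c1ccc(F)cc1` changes a different part of the molecule: fluoro in place of methyl on an aromatic carbon. Within the data shown here, no measured step touches this position, and the one measured step concerns another ring and lies within the scatter. Nothing in the data therefore points to a move in this assay in either direction beyond the scatter. Compound 3 is expected to land near compound 2, with an estimated 4700 nM and a range from 2300 nM to 9500 nM. The expected step of a 1.0-fold higher number from compound 2 to compound 3 (0.00 log units; within the scatter) is therefore one of no change beyond the scatter.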

Compound 3, concentration for 50% growth inhibition: 36400 nM
Beside the measured number, compound 3's estimate is 7.7-fold (0.89 log units) below it; the whole stated range lies below it.
By their numbers in this assay, from the lowest: compounds 2 and 1 (each within the scatter of the next); then compound 3.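

The position on the aromatic ring, para to a large group, turns out to matter in this assay: replacing methyl with fluoro gives a 7.8-fold higher number from compound 2 to compound 3 (0.89 log units; beyond the scatter) and so moves the compound toward weaker inhibition of growth. Within the data shown here, this is the first step in the set that lies beyond the scatter, whereas the only earlier step, on the benzyl ring, did not, so this ring is where the read-out has so far been seen to respond. The swap is small on paper, one heavy atom for one heavy atom with no ring, hydrogen-bond donor, hydrogen-bond acceptor or charge entering or leaving, and no measurement shown here explains why it shifts the number.

With a single pair, the data cannot say whether the methyl group favours growth inhibition or the fluoro group disfavours it, and a methoxy group, an ethyl group or a plain hydrogen at this spot would help to separate those readings. Also open, going by these compounds, is whether the same swap gives a similar step when the benzyl ring carries no chloro group, as in compound 1.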